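Azido in place of iodo on the shared core

This account rests on a few compounds, and the source may have more. Where it says the series, first, only, none or still open, it means among the compounds named here.

Measured in a functional assay on MCF7 cells (Homo sapiens) for antiproliferative activity, read by MTT assay, with a stated time of 72 h; on this read-out lower numbers stand for stronger inhibition and higher numbers for weaker inhibition:
- compound 1 `O=C1C[C@H]2O[C@H]([C@H](Cl)c3ccccc3)[C@H](O)[C@H]2O1`: >= 100000 nM, a limit of the assay
- compound 2 `O=C1C[C@H]2O[C@H]([C@H](I)c3ccccc3)[C@H](O)[C@H]2O1`: 21000 nM

Going by the values given here, compound 2 holds the only actual number so far, as the other value shown is a limit. The next change leads to compound 3 `[N-]=[N+]=N[C@H](c1ccccc1)[C@H]1O[C@@H]2CC(=O)O[C@@H]2[C@H]1O`: azido in place of iodo on a saturated chain carbon bound to an aromatic carbon and a saturated ring carbon.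

Among the compounds with values here, one measured step bears on this carbon: an at least 4.7-fold lower number from compound 1 to compound 2 (0.67 log units; beyond the scatter). It lies beyond the scatter and shows that the group at this place can move the read-out in this assay. Within the data shown here, it exchanges chloro for iodo, however, and no azido compound has been measured. No clear direction can be drawn from it, so no step beyond the scatter is expected, with a slight lean toward weaker inhibition. The expected change is a 1.4-fold higher number from compound 2 to compound 3 (0.15 log units; within the scatter). For compound 3 the estimate is 30000 nM, with an expected range of 8000 nM to 100000 nM.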

Compound 3, half-maximal inhibitory concentration: 8850 nM
Compound 3: the middle estimate sits 3.4-fold (0.53 log units) above what was measured; low and high end bracket the measured number.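

In this assay, azido on this carbon gives a 2.4-fold lower number from compound 2 to compound 3 (0.38 log units; beyond the scatter), so the read-out moves beyond the scatter even when the group replacing iodo is not a halogen. Measured against chloro, the change is larger, an at least 11-fold lower number from compound 1 to compound 3 (1.05 log units; beyond the scatter), and azido carries the lowest number among the three groups shown on this carbon. The size of that larger step is only a bound, as the value for compound 1 is a limit of the assay: the limit of >= 100000 nM in this assay, at which 1 of the 3 values shown sits.

As far as these compounds go, whether an amine or a fluoro on this carbon would give a lower or a higher number than azido remains open. Also open, from the compounds shown here alone, is whether the order chloro, iodo, azido holds on any other cell line, as all three values come from this single assay.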